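Adding a chloro group to compound 2

The compounds below may be only part of what the source reports. "The series", "measured", "known", "first", "only" and "open" are said of these compounds alone.

In an ADME assay on the whole organism (Mus musculus) for pharmacokinetics, at a dose of 10 mg/kg by the oral route (on this read-out lower numbers stand for lower exposure and higher numbers for higher exposure at the dose given), compound 1 (`CN(Cc1ccccc1)S(=O)(=O)c1ccc(NC(=O)NCc2ccncc2)cc1`) gives 12100 nM and compound 2 (`O=C(NCc1cn[nH]c1)Nc1ccc(S(=O)(=O)c2ccccc2)cc1`) gives 6260 nM, two values that lie within the usual scatter of each other. Compound 3 (`O=C(NCc1cn[nH]c1)Nc1ccc(S(=O)(=O)c2ccc(Cl)cc2)cc1`) carries chloro in place of hydrogen on an aromatic carbon of compound 2, para to a large group, turning phenyl to 4-chlorophenyl (chloro in place of hydrogen on an aromatic carbon). Among the measured compounds shown here, no pair of measured compounds shows this change, so no step beyond the scatter is expected in this assay, in either direction. The estimated change is a 1.0-fold lower number from compound 2 to compound 3 (0.02 log units; within the scatter). Compound 3 is expected at 6000 nM, with an estimated range from 2000 nM to 16000 nM.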

Compound 3, maximal plasma concentration: 24400 nM
The estimate for compound 3 lay 4.1-fold (0.61 log units) below the measured number, and the stated range ends below it.
By their numbers in this assay, from the lowest: compounds 2, 1 and 3 (each within the scatter of the next, the first and the last beyond it).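

Placed on an aromatic carbon of the six-membered ring, para to a large group, chloro in place of hydrogen gives a 3.9-fold higher number from compound 2 to compound 3 (0.59 log units; beyond the scatter), a step beyond the scatter. This shows that the position takes a single chlorine atom with a rise in the read-out, something compounds 1 and 2 could not show. Nothing at hand accounts for the rise.

From the compounds shown here alone, whether fluoro, methoxy or an amine at this position would move the number likewise remains open. So does whether chloro would give a similar step on another carbon of the ring.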